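Changing the aromatic substituent once more: expecting a flat step

A few compounds are considered here, and "the series" means these few. Any claim that something is new, unique, unknown or untested is made for them only; others in the source may bear on it.

Three compounds have been measured in an assay on CHO cells for displacement of a labelled ligand from adenosine receptor A1 (Homo sapiens), read by scintillation counting, tested at 10 uM; a lower number here means less inhibition, a higher number more inhibition at the concentration tested (going by the name of the read-out):

Compound 1, `CC(C)(C)Cc1c(-c2ccc(F)cc2)sc(N)c1C(=O)c1ccc(Cl)cc1`, gives 1%.
Compound 2, `CC(C)(C)Cc1c(-c2ccc(Cl)cc2)sc(N)c1C(=O)c1ccc(Cl)cc1`, gives 1%.
Compound 3, `COCCOc1ccc(-c2sc(N)c(C(=O)c3ccc(Cl)cc3)c2CC(C)(C)C)cc1`, gives 1%.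

Compound 3 stands level with compound 1 and compound 2 in this assay; every step among the three lies within the scatter, whether no change at the digits printed from compound 1 to compound 2 (within the scatter), no change at the digits printed from compound 1 to compound 3 (within the scatter) or no change at the digits printed from compound 2 to compound 3 (within the scatter). Each of those steps alters the same substituent on the aromatic carbon, and none moves the read-out.

Compound 4, `CC(C)(C)Cc1c(-c2ccc(OC(F)(F)F)cc2)sc(N)c1C(=O)c1ccc(Cl)cc1`, is not yet measured. It differs from compound 3 by trifluoromethyl in place of 2-methoxyethyl on an oxygen on an aromatic ring. The three measured steps bear directly on this, as they exchange the same substituent on that ring, and all were flat. The reasonable expectation is therefore no step beyond the scatter, with no change at the digits printed from compound 3 to compound 4 (within the scatter) as the expected change from compound 3 to compound 4. Compound 4 is thus estimated at 1%, with a range from -5% to 10%.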

Compound 4, a percentage reported as inhibition, at one concentration (the size of the read-out at that concentration, not a potency): 1%
The estimate for compound 4 equals the measured number at the digits printed; measured number inside the range.
By their numbers in this assay, from the lowest: compounds 1, 2, 3 and 4 (each within the scatter of the next).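

In this assay, within the data shown here, trifluoromethyl in place of 2-methoxyethyl gives no change at the digits printed from compound 3 to compound 4 (within the scatter) and so extends the flat picture to a change made on the oxygen itself, where the earlier steps all exchanged the whole substituent on the aromatic carbon. Trifluoromethoxy also gives no change at the digits printed from compound 2 to compound 4 (within the scatter) and no change at the digits printed from compound 1 to compound 4 (within the scatter) when set against chloro and fluoro, and the hydrogen-bond acceptor counted in 2-methoxyethyl, which trifluoromethyl lacks, leaves the read-out where it was. No supporting measurement is available to explain this flatness.

The compounds shown leave open whether any group on this aromatic ring, such as an amine or a carboxylic acid, can move the read-out at all. They also leave open whether a change elsewhere on the shared core would do so.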